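This account rests on a few compounds, and the source may have more. Where it says the series, first, only, none or still open, it means among the compounds named here.

In a functional assay on HeLa cells (Homo sapiens) for inhibition, with a stated time of 48 h, tested at 50 uM (a lower number here means less inhibition of growth, a higher number more inhibition of growth at the concentration tested), compound 1 (`C=C[C@@](C)(/C=C/c1ccc(OC(=O)CCCCCCCCC)cc1)CCC=C(C)C`) gives 50% and compound 2 (`C=C[C@@](C)(/C=C/c1ccc(O)c(N)c1)CCC=C(C)C`) gives 48%, while compound 3 (`C=C[C@@](C)(/C=C/c1ccc(O)cc1)CC/C=C(/C)C=O`) gives 40% at the same test concentration. Compound 3 stands within the scatter of both others, closest to compound 2, so the three cannot be ranked. Compound 4 (`C=C[C@@](C)(/C=C/c1ccc(O)cc1)CCC1OC1(C)C`) differs from compound 3 in one place, with 3,3-dimethyloxiran-2-yl in place of 2-formylprop-1-en-1-yl on a saturated chain carbon (3,3-dimethyloxiran-2-yl in place of 2-formylprop-1-en-1-yl on a saturated chain carbon, three bonds along the chain from two double-bonded chain carbons). Within the data shown here, no measured pair shows this change, so nothing beyond the scatter is expected in this assay in either direction. The estimated step (a number 2 percentage points higher from compound 3 to compound 4 (within the scatter)) is expected to stay small. Compound 4 is expected to give an estimated 42% with a likely range of 25% to 60% in this measurement.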

Compound 4, percent growth inhibition at one concentration: 32%
The estimate for compound 4 lay 10 percentage points above the measured number; the range from low to high includes it.
By their numbers in this assay, from the lowest: compounds 4, 3, 2 and 1 (each within the scatter of the next, the first and the last beyond it).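

In this assay, the exchange of 2-formylprop-1-en-1-yl for 3,3-dimethyloxiran-2-yl on a saturated chain carbon gives a number 8 percentage points lower from compound 3 to compound 4 (within the scatter), the first step read at this position. The open-chain group and the three-membered ring therefore cannot be told apart here, although one of them carries a ring and the other two double bonds. No available measurement bears on this result. This one step is all that speaks for the position. From the compounds shown here alone, whether a carboxylic acid or an amine on the same saturated chain carbon would move the number beyond the scatter remains open.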